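Swapping Oxan-4-yl for Piperidin-4-yl on Compound 1

This account rests on a few compounds, and the source may have more. Where it says the series, first, only, none or still open, it means among the compounds named here.

Of the compounds shown here, three sharing one core have so far been measured in a physicochemical assay for lipophilicity, read by HPLC, using the shake flask method, measured as octanol-water partition, at pH 7.4; on this read-out lower numbers stand for lower lipophilicity and higher numbers for higher lipophilicity. In this set, compound 1 `Cc1cc2ncccc2cc1Nc1ncc2c(n1)n(C1CCOCC1)c(=O)n2C` gives 2.5, compound 2 `Cc1cc2nnccc2cc1Nc1ncc2c(n1)n(C1CCOCC1)c(=O)n2C` gives 2.2 and compound 3 `Cc1cc2ncncc2cc1Nc1ncc2c(n1)n(C1CCOCC1)c(=O)n2C` gives 2.2. Compound 1 thus stands level with the other two, as both gaps lie within the usual scatter of repeated measurements.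

Compound 4 `Cc1cc2ncccc2cc1Nc1ncc2c(n1)n(C1CCNCC1)c(=O)n2C` keeps the core of compound 1 and carries piperidin-4-yl in place of oxan-4-yl on an aromatic nitrogen. Among the measured compounds shown here, no two measured compounds differ in only one place, and none of them varies this group, so the expectation rests on the structural change alone. A clear downward move in this assay is anticipated, well beyond the scatter. The expected step is a number 1.60 log units lower from compound 1 to compound 4 (beyond the scatter). For compound 4 the estimated value is 0.9, with an expected range from 0.3 to 1.5.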

Compound 4, distribution coefficient: 0.5
For compound 4 the middle estimate is 0.40 log units above the measured one; the range from low to high includes it.
By their numbers in this assay, from the lowest: compound 4; then compounds 2, 3 and 1 (each within the scatter of the next).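

Compound 1, compound 2 and compound 3 all carry oxan-4-yl on the aromatic nitrogen, so they gave no view of how this position behaves in this assay. Exchanging that group for piperidin-4-yl gives a number 2.00 log units lower from compound 1 to compound 4 (beyond the scatter) and shows that the read-out at this position can move by a large step, even though the two groups match in heavy-atom count and ring size and differ in the ring oxygen giving way to a ring nitrogen with a hydrogen-bond donor. The data shown offer no measured explanation for the size of this step.

Going by these compounds, whether a methyl group on the piperidine nitrogen, an open-chain amine or a carboxylic acid at this position would give a similar result remains open. On these data alone, it is also open whether the step carries over to compound 2 and compound 3.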